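Dipropylamino in place of azetidin-1-yl at the ring carbon

The compounds below may be only part of what the source reports. "The series", "measured", "known", "first", "only" and "open" are said of these compounds alone.

Compound 1 `O=C1C(Nc2ccccc2F)=CC(=O)c2c1nc1n2[C@H]2OC[C@@H](O)[C@H]2OC1` carries a (2-fluorophenyl)amino group on a double-bonded ring carbon of the shared core. In a functional assay on MCF7 cells (Homo sapiens) for inhibition, read by sulforhodamine B assay (on this read-out lower numbers stand for stronger inhibition and higher numbers for weaker inhibition), compound 1 reaches only a limit of > 4000 nM. Compound 3 `O=C1C(N2CCCC2)=CC(=O)c2c1nc1n2[C@H]2OC[C@@H](O)[C@H]2OC1` carries pyrrolidin-1-yl at that carbon instead. In this assay compound 3 likewise stops at a limit of > 16000 nM. The step that the two limits leave unreadable from compound 1 to compound 3 cannot be sized because the limit of > 4000 nM in this assay, at which 1 of the 3 values shown sits, and the limit of > 16000 nM in this assay, at which 2 of the 3 values shown sit, leave no number on either side of it.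

Compound 2 `O=C1C=C(N2CCC2)C(=O)c2c1nc1n2[C@H]2OC[C@@H](O)[C@H]2OC1` bears azetidin-1-yl at the same carbon. In this assay compound 2 also gives only a limit of > 16000 nM. Two of the three values shown sit at the same limit as compound 2 and the third at a lower one, so compound 2 is placed by a limit only and no number sets it apart from the others.

Compound 4 `CCCN(CCC)C1=CC(=O)c2nc3n(c2C1=O)[C@H]1OC[C@@H](O)[C@H]1OC3` differs from compound 2 by dipropylamino in place of azetidin-1-yl on a double-bonded ring carbon. Within the data shown here, the only measured step that swaps the amine on that carbon, from compound 1 to compound 3, is of unreadable size, so no measured step points to a change in this assay beyond the scatter in either direction. Compound 4 is expected to give 20000 nM, within 5000 nM to 80000 nM, most probably as a limit once more. The expected change is a step that the limit leaves unreadable from compound 2 to compound 4.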

Compound 4, half-maximal inhibitory concentration: > 16000 nM
Compound 4: only a limit was reported; the forecaster's own chance of this, stated with the estimate: 80%; the middle value lies beyond the limit too.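

In this assay compound 4 gives only a limit of > 16000 nM. Compound 2 also stops at a limit, so no step can be read between compound 2 and compound 4. The compounds shown leave open whether the amine on that double-bonded ring carbon changes inhibition at all in this assay; all four values shown are limits.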